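Sulfur-linked aryl swap on a diaminoquinoxaline core

The compounds below may be only part of what the source reports. "The series", "measured", "known", "first", "only" and "open" are said of these compounds alone.

Measured compounds in a functional assay on MDA-MB-231 cells (Homo sapiens) for inhibition, read by sulforhodamine B assay, with a stated time of 48 h; on this read-out higher numbers stand for lower toxicity in this test and lower numbers for higher toxicity in this test:
compound 1 `Nc1cc(N)c2nc(-c3ccccc3)c(Oc3ccc(Cl)c(Cl)c3)nc2c1`: 66100 nM
compound 2 `Nc1cc(N)c2nc(-c3ccccc3)c(NCc3ccc(F)cc3)nc2c1`: 19500 nM
compound 3 `Nc1cc(N)c2nc(-c3ccccc3)c(Sc3ccc(Cl)c(Cl)c3)nc2c1`: < 100000 nM

For compound 3 the value in this assay is a limit of the assay, not a number, as noted in the limit of < 100000 nM in this assay, at which 1 of the 3 values shown sits. The steps a step that the limit leaves unreadable from compound 1 to compound 3 and a step that the limit leaves unreadable from compound 2 to compound 3 are therefore unreadable in size. For the measured compounds named here, the only readable step, a 3.4-fold lower number from compound 1 to compound 2 (0.53 log units; beyond the scatter), pairs a change of linker with a change of halogen pattern and is modest. Compound 4 `Nc1cc(N)c2nc(-c3ccccc3)c(Sc3ccc(F)cc3)nc2c1` differs from compound 3 by 4-fluorophenyl in place of 3,4-dichlorophenyl on a sulfur. Since compound 3 itself stands only at a limit, the step that the limit leaves unreadable from compound 3 to compound 4 is an expectation resting on compound 1 and compound 2 alone. Compound 4 is estimated at 40000 nM, between 10000 nM and 100000 nM.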

Compound 4, concentration lethal to 50% of the cells: 83200 nM
Beside the measured number, compound 4's estimate is 2.1-fold (0.32 log units) below it, and the stated range covers the measured number.
By their numbers in this assay, from the lowest: compound 2; then compounds 1 and 4 (each within the scatter of the next).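

In this assay a sulfur link at this position now has a readable number: the (4-fluorophenyl)sulfanyl group shows a 4.3-fold higher number from compound 2 to compound 4 (0.63 log units; beyond the scatter) in place of the (4-fluorobenzyl)amino group and a 1.3-fold higher number from compound 1 to compound 4 (0.10 log units; within the scatter) in place of the 3,4-dichlorophenoxy group. Compound 4 thus cannot be told apart from compound 1, while compound 2 stands clear of it. Compound 3 remains a limit, so every step to it stays unreadable: the limit of < 100000 nM in this assay, at which 1 of the 4 values shown sits.

Going by these compounds, whether a carboxylic acid or an amine on the aryl group at the sulfur, or a longer chain in place of that aryl group, would move the number remains open.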